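Swapping the aryl on the ring nitrogen: a pyridyl variant

A few compounds are considered here, and "the series" means these few. Any claim that something is new, unique, unknown or untested is made for them only; others in the source may bear on it.

Measured compounds:
- compound 1 `COc1ccc(N2CCN(C(=S)SCc3ccc4nc(N)nc(N)c4c3)CC2)cc1`: 2270 nM
- compound 2 `Cc1ccc(N2CCN(C(=S)SCc3ccc4nc(N)nc(N)c4c3)CC2)cc1`: 5510 nM

In a functional assay on HCT-116 cells (Homo sapiens) for antiproliferative activity, read by MTT assay, with a stated time of 72 h (on this read-out higher numbers stand for weaker inhibition and lower numbers for stronger inhibition), compound 1 gives 2270 nM, the lowest of the two numbers; its nearest neighbour is compound 2, where the step of a 2.4-fold higher number from compound 1 to compound 2 (0.39 log units; beyond the scatter) comes from a methyl in place of methoxy on an aromatic carbon. Compound 3 `Nc1nc(N)c2cc(CSC(=S)N3CCN(c4ccccn4)CC3)ccc2n1` differs from compound 1 at a different site: pyridin-2-yl in place of 4-methoxyphenyl on an amine nitrogen in a ring, on an amine nitrogen in a ring of a six-membered non-aromatic ring with 2 nitrogen. Within the data shown here, no measured step touches this position; the only step available, from compound 1 to compound 2, concerns a substituent on the aromatic ring that now leaves entirely, and it was modest. The expectation is therefore for compound 3 a step of a 1.5-fold higher number from compound 1 to compound 3 (0.19 log units; within the scatter) that may reach beyond the scatter but not by much. Compound 3 is estimated at 3500 nM, within 1200 nM to 10000 nM.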

Compound 3, half-maximal inhibitory concentration: 5960 nM
For compound 3 the middle estimate is 1.7-fold (0.23 log units) below the measured one; measured number inside the range.
By their numbers in this assay, from the lowest: compound 1; then compounds 2 and 3 (each within the scatter of the next).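

In this assay, pyridin-2-yl in place of 4-methoxyphenyl on the amine nitrogen in a ring gives a 2.6-fold higher number from compound 1 to compound 3 (0.42 log units; beyond the scatter), so this position does respond to the exchange of the whole aryl group, though only modestly. Against 4-methylphenyl, the same pyridin-2-yl gives a 1.1-fold higher number from compound 2 to compound 3 (0.03 log units; within the scatter), which leaves compound 2 and compound 3 indistinguishable, and among these three aryl groups only the 4-methoxyphenyl of compound 1 stands apart. No accompanying measurement explains this difference.

The compounds shown do not separate the loss of the methoxy group from the entry of the ring nitrogen, since compound 3 changes both at once. A plain phenyl, a 4-hydroxyphenyl or a methoxy-bearing pyridine would be needed to tell these two contributions apart.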